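Pyridin-4-yl for Phenyl on the Ring Nitrogen Substituent

The source may hold more compounds than are shown below. What is called first, only, known or untested is meant among the compounds shown, and "the series" means these compounds.

Measured compounds:
compound 1, `Clc1cc(Cl)cc(CO[C@H]2CCCN(Cc3ccccc3)[C@H]2c2ccccc2)c1` — > 200000 nM
compound 2, `O=C(O)c1ccc(CN2CCC[C@H](O[C@H](CO)c3cc(Cl)cc(Cl)c3)[C@@H]2c2ccccc2)cc1` — 11000 nM

Both were tested in an assay on isolated protein for activation of cGMP-dependent protein kinase 1 (Homo sapiens), read by ADP-Glo, with stated times of 120 min and 40 min; on this read-out lower numbers stand for an effect already at smaller amounts and higher numbers for an effect only at larger amounts of compound. For compound 1 the value > 200000 nM is a limit of the assay and not a number. On the numbers shown compound 1 therefore stands only at the limit of > 200000 nM in this assay, at which 1 of the 2 values shown sits. Compound 2 differs from compound 1 in more than one place; in this assay compound 2 gives a number, 11000 nM. Within the data shown here, no single step between these two compounds can be read from them, so their two values are simply what each shows.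

The unmeasured compound 3, `Clc1cc(Cl)cc(CO[C@H]2CCCN(Cc3ccncc3)[C@H]2c2ccccc2)c1`, differs from compound 1 by a single change: pyridin-4-yl in place of phenyl on a saturated chain carbon bound to an amine nitrogen in a ring. Among the measured compounds shown here, no measured pair shows the effect of this exchange, so the expectation rests on compound 1 alone. The author expects no shift beyond the usual scatter, and the estimated step of a number no higher from compound 1 to compound 3 (the limit leaves the size open) reflects that. Compound 3 is therefore expected to give about 200000 nM, with a range from 50000 nM to 1000000 nM, and most likely again only a limit rather than a number.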

Compound 3, half-maximal effective concentration: > 200000 nM
Compound 3: no number, only a limit; the forecaster's own chance of this, stated with the estimate: 70%; the middle value lies on the limit itself.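

Compound 3 gives > 200000 nM as a limit of the assay and not a number. Among these compounds, compound 1 also stands only at a limit, so no step from compound 1 to compound 3 can be read. The compounds shown leave open whether pyridin-4-yl in place of phenyl at this place changes the read-out at all.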